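Swapping Chloro for Trifluoromethyl on a Fused Ring

This account rests on a few compounds, and the source may have more. Where it says the series, first, only, none or still open, it means among the compounds named here.

Compound 1 `O=C(O)Cc1nn(Cc2nc3c(Cl)cccc3s2)c(=O)c2ccccc12`, compound 2 `O=C(O)Cc1nn(Cc2nc3c(C(F)(F)F)cccc3s2)c(=O)c2ccccc12` and compound 3 `O=C(O)Cc1nn(Cc2nc3cc(Cl)cc(Cl)c3s2)c(=O)c2ccccc12` have been tested in an in vivo functional assay on the whole organism for inhibition of sorbitol dehydrogenase (Rattus norvegicus), at a dose of 10 mg/kg by the oral route; a higher number here means more inhibition at the dose given (going by the name of the read-out), a lower number less inhibition. Compound 1 gives 63%, compound 2 gives 61% and compound 3 gives 73%. The change from compound 1 to compound 2 is trifluoromethyl in place of chloro on an aromatic carbon; it made a number 2 percentage points lower from compound 1 to compound 2 (within the scatter). Compound 4 `O=C(O)Cc1nn(Cc2nc3cc(C(F)(F)F)cc(Cl)c3s2)c(=O)c2ccccc12` has not yet been measured. It arises from compound 3 by trifluoromethyl in place of chloro on an aromatic carbon. Within the data shown here, this is the same kind of change as the one from compound 1 to compound 2, but not the same: in compound 2 the entering group sits ortho to a fused ring and meta to a fused ring, whereas in compound 4 it sits meta to a chloro group, meta to a fused ring and para to a fused ring. How the core of compound 3 differs from the core of compound 1 is not broken down here. Because the matching step was a number 2 percentage points lower from compound 1 to compound 2 (within the scatter), the step expected here is a number 2 percentage points lower from compound 3 to compound 4 (within the scatter). The estimate for compound 4 in this assay is 71%, with a range from 58% to 82%.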

Compound 4, a percentage reported as inhibition, in the whole organism at one dose (the size of the read-out at that dose, not a potency): 26%
The estimate for compound 4 lay 45 percentage points above the measured number; measured number outside the range, below it.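

Trifluoromethyl in place of chloro on an aromatic carbon gives a number 47 percentage points lower from compound 3 to compound 4 (beyond the scatter) in this assay. This change therefore does not behave as a fixed step that can be carried unaltered from one core to another in this series: the same change on two cores in this assay, a number 2 percentage points lower (within the scatter) from compound 1 to compound 2 and a number 47 percentage points lower (beyond the scatter) from compound 3 to compound 4, 45 percentage points apart, beyond the scatter of two such steps

What this does not show is why the two steps differ: the entering group sits in a different place in each pair and the cores differ as well, so these two pairs cannot separate those influences, and a read-out from a whole organism at one dose does not say which part of the compound's journey to the enzyme changed.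

On the core of compound 3, only chloro and trifluoromethyl are shown at this place, so it remains open how a smaller or differently built group, such as a methyl, a methoxy or a nitrile, would fare there. From the compounds shown here alone, it also remains open how the swap would behave at the other chloro group of compound 3.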